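The source may report more compounds than this note shows. Statements on the series, on what has been measured and on what is new or still open speak of the compounds shown alone.

Working notes on the series.

Compound 1 `COc1cccc2c(=O)c(Cc3ccccc3)c(C)[nH]c12` in an ADME assay on J774 cells (Mus musculus) for cytotoxicity (a lower number here means that less compound is needed, a higher number that more compound is needed for the effect), reaches only the limit of the assay, > 35800 nM. Compound 2 `Cc1[nH]c2c(Cl)cccc2c(=O)c1Cc1ccccc1` likewise gives a limit in this assay, > 35200 nM. The change between them is chloro in place of methoxy on an aromatic carbon, and the step that the two limits leave unreadable from compound 1 to compound 2 cannot be read because the limit of > 35800 nM in this assay, at which 2 of the 3 values shown sit, and the limit of > 35200 nM in this assay, at which 1 of the 3 values shown sits, are where the two values sit. Compound 3 `COc1ccc2c(=O)c(Cc3ccccc3)c(C)[nH]c2c1` also stops at a limit in this assay, > 35800 nM; how its core differs from the core of compound 1 is not broken down here. Compound 4 `Cc1[nH]c2cc(Cl)ccc2c(=O)c1Cc1ccccc1` is not yet measured; it differs from compound 3 by chloro in place of methoxy on an aromatic carbon, the same kind of change as from compound 1 to compound 2, but here the place is meta to a fused ring and para to a fused ring rather than ortho to a fused ring and meta to a fused ring. Since compound 3 gives > 35800 nM, a limit, the step that the limit leaves unreadable from compound 3 to compound 4 is expected to be unreadable, and compound 4 is expected at 40000 nM, most likely again a limit.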

Compound 4, half-maximal effective concentration: > 35200 nM
Compound 4 ended at the assay's limit; the forecaster's own chance of this, stated with the estimate: 85%; the middle value lies beyond the limit too.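

Within the data shown here, compound 3 and compound 4 both stop at limits in this assay, and no step between them can be read. The compounds shown leave open whether chloro and methoxy differ at all in this assay, at either place.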